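This account rests on a few compounds, and the source may have more. Where it says the series, first, only, none or still open, it means among the compounds named here.

Compound 1 `C=C(CCCCCCC)c1c(C)[nH]c2ccccc2c1=O` gives 1760 10^-6 cm/s
Compound 2 `CCc1c(C)[nH]c2cc(OC)c(Cl)cc2c1=O` gives 96.4 10^-6 cm/s
Compound 3 `CCc1c(C)[nH]c2cc(OC)c(Br)cc2c1=O` gives 81.9 10^-6 cm/s

In an ADME assay for permeability, using PAMPA, at pH 4 (on this read-out lower numbers stand for lower permeability and higher numbers for higher permeability), compound 2 stands second highest of the three numbers. Its nearest neighbour is compound 3, reached by a 1.2-fold lower number from compound 2 to compound 3 (0.07 log units; within the scatter); its furthest is compound 1, whose number lies far above, well beyond the scatter.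

Compound 4 `COc1cc2[nH]c(C)c(C(C)C)c(=O)c2cc1Cl` differs from compound 2 by methyl in place of hydrogen on a saturated chain carbon bound to an aromatic carbon and a saturated chain carbon. Within the data shown here, the only measured step, the halogen swap from compound 2 to compound 3, does not touch this chain and stayed within the scatter, so no measured step bears directly on the change. With compounds 2 and 3 close together and nothing on chain branching, a step no larger than the scatter is expected, a 1.2-fold higher number from compound 2 to compound 4 (0.10 log units; within the scatter). Compound 4 is therefore estimated at 120 10^-6 cm/s, ranging from 60 10^-6 cm/s to 240 10^-6 cm/s.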

Compound 4, apparent permeability: 281 10^-6 cm/s
The estimate for compound 4 lay 2.3-fold (0.37 log units) below the measured number; measured number outside the range, above it.
By their numbers in this assay, from the lowest: compounds 3 and 2 (each within the scatter of the next); then compound 4; then compound 1.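

Unlike the halogen swap (a 1.2-fold lower number from compound 2 to compound 3 (0.07 log units; within the scatter)), ethyl to isopropyl on the saturated chain carbon moves the number in this assay beyond the scatter (a 2.9-fold higher number from compound 2 to compound 4 (0.46 log units; beyond the scatter)), although the step is modest. Among these compounds, this shows that the number responds to one added methyl at this carbon, a change the earlier compounds did not cover. No measurement shown accounts for this higher number.

As far as these compounds go, whether a tert-butyl group or a longer chain at this carbon would raise the number further remains open, as does the step an amine there would give. A single branched compound also cannot show whether the step holds with bromo in place of chloro.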